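From 2,3-dichlorophenyl to 2-chlorophenyl: one chloro fewer

A few compounds are considered here, and "the series" means these few. Any claim that something is new, unique, unknown or untested is made for them only; others in the source may bear on it.

Measured in a functional assay on A549 cells (Homo sapiens) for antiproliferative activity, read by MTT assay, with a stated time of 72 h; on this read-out lower numbers stand for stronger inhibition and higher numbers for weaker inhibition:
- compound 1 `COc1ccc(OCCCON2C(N)=NC(N)=NC23CCOCC3)cc1`: 660 nM
- compound 2 `NC1=NC2(CCOCC2)N(OCCCOc2ccc(Cl)cc2)C(N)=N1`: 360 nM
- compound 3 `NC1=NC2(CCOCC2)N(OCCCOc2cccc(Cl)c2Cl)C(N)=N1`: 100 nM

Among these three, compound 3 has the lowest number, which here means the strongest inhibition, and its steps to both others lie beyond the scatter. Compound 4 `NC1=NC2(CCOCC2)N(OCCCOc2ccccc2Cl)C(N)=N1` has not yet been measured in this assay. It differs from compound 3 in one place: hydrogen in place of chloro on an aromatic carbon. This is hydrogen in place of chloro on an aromatic carbon, turning 2,3-dichlorophenyl into 2-chlorophenyl.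

Among the measured compounds shown here, no measured step removes this chloro alone. The nearest guide is a 3.6-fold lower number from compound 2 to compound 3 (0.56 log units; beyond the scatter), where 2,3-dichlorophenyl replaces 4-chlorophenyl. A looser guide is a 6.6-fold lower number from compound 1 to compound 3 (0.82 log units; beyond the scatter), where it replaces 4-methoxyphenyl. Both point to a modest rise in the number when the second chloro goes. The expected step is a 2.1-fold higher number from compound 3 to compound 4 (0.32 log units; beyond the scatter). For compound 4 the estimate is 210 nM, with an expected range from 90 nM to 480 nM.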

Compound 4, half-maximal inhibitory concentration: 2700 nM
Beside the measured number, compound 4's estimate is 13-fold (1.11 log units) below it; the whole stated range lies below it.
By their numbers in this assay, from the lowest: compound 3; then compounds 2 and 1 (each within the scatter of the next); then compound 4.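

In this assay, among the compounds shown here, this single chloro matters far more than the earlier compounds showed: removing it gives a 27-fold higher number from compound 3 to compound 4 (1.43 log units; beyond the scatter), so the chloro left in 2-chlorophenyl does not by itself keep the number low. The count of chloro groups does not settle the matter either, since 2-chlorophenyl in place of 4-chlorophenyl gives a 7.5-fold higher number from compound 2 to compound 4 (0.88 log units; beyond the scatter), although both groups carry one chloro, and 2-chlorophenyl in place of 4-methoxyphenyl gives a 4.1-fold higher number from compound 1 to compound 4 (0.61 log units; beyond the scatter). Why removing this chloro costs so much cannot be said from the information available.

Going by these compounds, it remains open whether this aromatic carbon needs chloro specifically, or whether a bromo or a methyl group there would keep the number as low as in compound 3. On these data alone, the effect of a longer chain between the two oxygens on these aromatic patterns also remains open.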